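Oleyl ketone series: aromatic group on the carbonyl carbon

A few compounds are considered here, and "the series" means these few. Any claim that something is new, unique, unknown or untested is made for them only; others in the source may bear on it.

Compound 3 `CCCCCCCC/C=C\CCCCCCC(=O)c1ccccc1` sits at a limit of an assay on isolated protein for inhibition of Fatty-acid amide hydrolase 1 (Homo sapiens) (a lower number here means a stronger inhibitor, a higher number a weaker inhibitor), giving > 100000 nM. Compound 1 `CCCCCCCC/C=C\CCCCCCC(=O)c1ccccn1` likewise gives only a limit, > 100000 nM. Compound 2 `CCCCCCCC/C=C\CCCCCCC(=O)c1nnn(C)n1` gives a number, 65 nM. Both limits lie at the limit of > 100000 nM in this assay, at which 2 of the 3 values shown sit. The step of an at least 1500-fold higher number from compound 2 to compound 3 (3.18 log units; beyond the scatter) and the step of an at least 1500-fold lower number from compound 1 to compound 2 (3.18 log units; beyond the scatter) show that exchanging the aromatic group on the carbonyl carbon can move the value across the whole readable range. Compound 4 `CCCCCCCC/C=C\CCCCCCC(=O)c1nc2cccnc2o1` carries a group of 9 heavy atoms (6 carbon, 2 nitrogen, 1 oxygen; one five-membered aromatic ring with 2 hetero atoms, one six-membered aromatic ring with 1 hetero atom) in place of a group of 6 heavy atoms (6 carbon; one six-membered aromatic ring of carbon only), on a carbonyl carbon. Among the measured compounds shown here, since the only measured exchange toward a nitrogen-rich five-membered ring, the one from compound 3 to compound 2, was large, a large fall in this assay is expected, an at least 20000-fold lower number from compound 3 to compound 4 (4.30 log units; beyond the scatter). Compound 4 is therefore estimated at 5 nM, within 0.5 nM to 50 nM.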

Compound 4, inhibition constant: 11 nM
The estimate for compound 4 lay 2.2-fold (0.34 log units) below the measured number, and the stated range covers the measured number.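

Compound 2 no longer stands alone: a second group on the carbonyl carbon, holding a five-membered aromatic ring with 2 hetero atoms and a six-membered aromatic ring with 1 hetero atom, also gives a readable value in this assay, and a 5.9-fold lower number from compound 2 to compound 4 (0.77 log units; beyond the scatter) is a further gain over the 2-methyl-2H-tetrazol-5-yl group. The steps of an at least 9000-fold lower number from compound 3 to compound 4 (3.95 log units; beyond the scatter) and an at least 9000-fold lower number from compound 1 to compound 4 (3.95 log units; beyond the scatter) are bounds only, because each starts from a limit: the limit of > 100000 nM in this assay, at which 2 of the 4 values shown sit. On these data alone, whether the five-membered ring alone would suffice remains open, as does the effect of a carboxylic acid or an amine on the six-membered ring of compound 4.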